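The source may hold more compounds than are shown below. What is called first, only, known or untested is meant among the compounds shown, and "the series" means these compounds.

Measured compounds:
- compound 1, `CCCCCCCCCCCCCCCCCC(=O)C(F)(F)F`: 240 nM
- compound 2, `CCCCCCCC/C=C\CCCCCCC(=O)c1nnn(C)n1`: 65 nM
- compound 3, `CCCCCCCC/C=C\CCCCCCC(=O)c1nc2cc(C)ccc2o1`: > 100000 nM

In an assay on isolated protein for inhibition of Fatty-acid amide hydrolase 1 (Homo sapiens) (on this read-out higher numbers stand for weaker inhibition and lower numbers for stronger inhibition), compound 2 gives the lowest of the two numbers shown. Its nearest neighbour, compound 1, gives 240 nM, a gap that lies beyond the scatter. For compound 3 the result is a limit, not a number: the limit of > 100000 nM in this assay, at which 1 of the 3 values shown sits. Among the shown compounds the heteroaryl ketones of the same unsaturated chain thus spread from a low number to a limit, and no step between measured compounds is available to size any single change.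

Compound 4, `CCCCCCCC/C=C\CCCCCCC(=O)c1ncco1`, is not yet measured. 1,3-oxazol-2-yl in place of 2-methyl-2H-tetrazol-5-yl on a carbonyl carbon

With so few measured points to go on, the expectation for compound 4 rests on compound 2, 65 nM, as the closest measured point. The step from compound 2 to compound 4 is expected to be a 1.3-fold lower number from compound 2 to compound 4 (0.11 log units; within the scatter), small and of uncertain direction, within or close to the scatter. Compound 4 is therefore estimated at 50 nM, with a range from 8 nM to 300 nM.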

Compound 4, inhibition constant: 17 nM
Compound 4: middle estimate off by 2.9-fold (0.47 log units), on the high side; the range from low to high includes it.
By their numbers in this assay, from the lowest: compound 4; then compound 2; then compound 1. At a limit, above all of these: compound 3.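

In this assay, within the data shown here, 1,3-oxazol-2-yl in place of 2-methyl-2H-tetrazol-5-yl on a carbonyl carbon gives a 3.8-fold lower number from compound 2 to compound 4 (0.58 log units; beyond the scatter), the first sized change at this position. With the unsaturated chain held fixed, the group on the carbonyl carbon alone moves the number beyond the scatter, and here the ring with 2 hetero atoms gives the lower number than the ring with 4. Compound 3 carries the same chain with another group at this position, and its result is a limit, not a number: the limit of > 100000 nM in this assay, at which 1 of the 4 values shown sits.

The compounds shown do not separate which difference between the two rings drives the step. Also open, as far as these compounds go, is whether the number for compound 4 holds with a carboxylic acid or a pyridine ring added to the 1,3-oxazol-2-yl group, or with a shorter chain.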